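The source may report more compounds than this note shows. Statements on the series, on what has been measured and on what is new or still open speak of the compounds shown alone.

Measured so far in an in vivo ADME assay on the whole organism (strain Sprague-Dawley) for pharmacokinetics, with Rattus norvegicus as the target; a higher number here means that more of the compound sits outside the plasma, a lower number that more of the compound stays in the plasma:
- Compound 1 `O=C1[C@@H](NS(=O)(=O)c2ccc3c(Cl)c[nH]c3c2)CCN1c1ccc2c(c1)CCNC2`: 2.9 L/kg
- Compound 2 `O=C1[C@@H](NS(=O)(=O)/C=C/c2ccc(Cl)s2)CCN1c1ccc2c(c1F)CCNC2`: 0.9 L/kg

In this assay, compound 2 has the lower of the two numbers, and the gap up to compound 1 lies beyond the usual scatter. Compound 3 `O=C1[C@@H](NS(=O)(=O)c2ccc3c(Cl)c[nH]c3c2)CCN1c1ccc2c(c1F)CCNC2` has not yet been measured. It differs from compound 2 at one place: 3-chloro-1H-indol-6-yl in place of 2-(5-chlorothiophen-2-yl)ethenyl on a sulfonyl sulfur. In words, 3-chloro-1H-indol-6-yl stands in place of 2-(5-chlorothiophen-2-yl)ethenyl on a sulfonyl sulfur. Among the measured compounds shown here, no step between measured compounds isolates this change, so the expectation rests on a single comparison. Compound 1 carries the same 3-chloro-1H-indol-6-yl and gives 2.9 L/kg, which suggests that compound 3 should land nearer to that number. The estimated change is a 2.7-fold higher number from compound 2 to compound 3 (0.43 log units; beyond the scatter), an expected rise beyond the scatter. For compound 3 the expected value is 2.4 L/kg, with an estimated range of 1.2 L/kg to 4.8 L/kg.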

Compound 3, volume of distribution at steady state: 1.5 L/kg
Compound 3: the middle estimate sits 1.6-fold (0.20 log units) above what was measured; low and high end bracket the measured number.
By their numbers in this assay, from the lowest: compounds 2, 3 and 1 (each within the scatter of the next, the first and the last beyond it).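

In this assay, 3-chloro-1H-indol-6-yl in place of 2-(5-chlorothiophen-2-yl)ethenyl on a sulfonyl sulfur gives a 1.7-fold higher number from compound 2 to compound 3 (0.22 log units; within the scatter), so with the fluoro present, this exchange of two quite different groups cannot be told from the scatter. Fluoro in place of hydrogen on an aromatic carbon gives a 1.9-fold lower number from compound 1 to compound 3 (0.29 log units; within the scatter), and this step, too, cannot be told from the scatter. Each of the two changes can now be read on its own, and neither alone shows a clear effect on the volume of distribution.

Going by these compounds, whether the same holds for other groups on the sulfonyl sulfur, such as a plain phenyl or a chain ending in a carboxylic acid, stays open. On these data alone, it is also open whether chloro or methyl in place of the fluoro would give a step beyond the scatter. No measurement at hand explains any of these numbers.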